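The source may hold more compounds than are shown below. What is called first, only, known or untested is meant among the compounds shown, and "the series" means these compounds.

Measured compounds:
- compound 1, `CC(C)(C)c1ccc(CNC(=O)Nc2cccc3cnccc23)cc1`: 13.8 nM
- compound 2, `CC1CCN(c2nc(C(F)(F)F)ccc2CNC(=O)Nc2cccc3cccnc23)CC1`: 91.6 nM

Of the compounds shown here, two have been measured in an assay on isolated protein for antagonist activity at transient receptor potential cation channel subfamily V member 1 (Homo sapiens), read by FLIPR; on this read-out lower numbers stand for stronger inhibition and higher numbers for weaker inhibition. Compound 1 gives 13.8 nM, while compound 2 gives 91.6 nM, the higher of the two numbers, so compound 2 is the weaker inhibitor of this pair, and the gap between the two lies beyond the usual scatter of the assay. The two structures share the urea linkage but differ at several points, so no single change can be tied to that gap.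

Compound 3, `CC1CCN(c2nc(C(F)(F)F)ccc2CNC(=O)Nc2cccc3nccnc23)CC1`, has not yet been measured. It differs from compound 2 in one place only: quinoxalin-5-yl in place of quinolin-8-yl on an amide-type nitrogen. The change is quinoxalin-5-yl in place of quinolin-8-yl on an amide-type nitrogen, the rest of the molecule being unchanged.

Going by the values given here, no measured pair shows the effect of this exchange, so there is no step to draw on. The expectation is a modest step from compound 2 to compound 3, a 1.3-fold higher number from compound 2 to compound 3 (0.12 log units; within the scatter), most likely within the scatter or slightly towards a weaker inhibitor. Compound 3 is therefore estimated at 120 nM, with a range from 40 nM to 400 nM.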

Compound 3, inhibition constant: 48.1 nM
Estimate against measurement, compound 3: 2.5-fold (0.40 log units) above; low and high end bracket the measured number.
By their numbers in this assay, from the lowest: compound 1; then compounds 3 and 2 (each within the scatter of the next).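

In this assay, quinoxalin-5-yl in place of quinolin-8-yl on the amide-type nitrogen gives a 1.9-fold lower number from compound 2 to compound 3 (0.28 log units; within the scatter), so this read-out does not separate the two groups. The exchange keeps 10 heavy atoms but goes from 1 nitrogen to 2 and from 1 hydrogen-bond acceptor to 2, which shows that, with the rest of the molecule unchanged, this place accepts that difference without a step beyond the scatter. No measurement shown here explains why the two groups give numbers this close.

Going by these compounds alone, it remains open whether the same exchange would give a similar step in a molecule with a different other half, such as the one carrying the tert-butyl group in compound 1. Also open, from the compounds shown here alone, is what would happen if the group on this nitrogen were a plain phenyl ring, or if the quinoxalin-5-yl carried a further substituent such as an amine or a hydroxyl group.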